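The compounds below may be only part of what the source reports. "The series", "measured", "known", "first", "only" and "open" are said of these compounds alone.

Measured compounds and their values in a functional assay on the whole organism (Ehrlich cells, Mus musculus) for antiproliferative activity, with a stated time of 24 h, at a dose of 0.2 mmol/kg by the intraperitoneal route; a lower number here means less inhibition, a higher number more inhibition at the dose given (going by the name of the read-out):
compound 1 `Nc1ccccc1NC(=O)CCCNCC(=O)Nc1ccc(Br)cc1` gives 73.8%
compound 2 `Nc1ccccc1NC(=O)c1ccc(NCC(=O)Nc2ccc([N+](=O)[O-])cc2)cc1` gives 83.3%
compound 3 `Nc1ccccc1NC(=O)CCCNCC(=O)Nc1cc(Cl)ccc1Cl` gives 50%

Compound 2 stands highest of these three numbers in this assay, with compound 1 within the scatter of it and compound 3 beyond it. Compound 4 `COc1ccc(NC(=O)CNc2ccc(C(=O)Nc3ccccc3N)cc2)cc1` differs from compound 2 by methoxy in place of nitro on an aromatic carbon. For the measured compounds named here, the only measured step, a number 23.8 percentage points lower from compound 1 to compound 3 (beyond the scatter), swaps the whole aryl group on a different core, so it bears only loosely on this change; no measured pair isolates a single substituent on that ring. The step is therefore expected to stay within the scatter or fall modestly, as a number 8.3 percentage points lower from compound 2 to compound 4 (within the scatter). Compound 4 is estimated at 75%, between 55% and 90%.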

Compound 4, a percentage reported as inhibition, in the whole organism at one dose (the size of the read-out at that dose, not a potency): 66.6%
The estimate for compound 4 lay 8.4 percentage points above the measured number; measured number inside the range.
By their numbers in this assay, from the lowest: compound 3; then compounds 4, 1 and 2 (each within the scatter of the next, the first and the last beyond it).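

In this assay, methoxy in place of nitro on an aromatic carbon, para to a large group, gives a number 16.7 percentage points lower from compound 2 to compound 4 (beyond the scatter). This is the only step shown that changes a single group on this ring, and it shows that the read-out at this dose responds to which group sits at this position. Nothing shown bears on why the number falls. Open, on these data alone, is whether an amine or a trifluoromethyl group here would read nearer compound 2 or compound 4. Also open, as far as these compounds go, is whether the same change on the core of compound 1 would give a step of similar size.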